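Cyclopropane amide series: ester versus hydroxymethyl, cytotoxicity

This account rests on a few compounds, and the source may have more. Where it says the series, first, only, none or still open, it means among the compounds named here.

Compound 2 `COc1cc([C@H]2C[C@@]2(CO)C(=O)Nc2ccccc2)cc(OC)c1OC` carries a hydroxymethyl on the shared core and a plain phenyl amide; compound 1 `CCOC(=O)[C@@]1(C(=O)Nc2ccccc2)C[C@@H]1c1cc(OC)c(OC)c(OC)c1` differs from it by ethoxycarbonyl in place of hydroxymethyl on a saturated ring carbon. In a functional assay on HeLa cells (Homo sapiens) for cytotoxicity, read by MTT assay, with a stated time of 48 h (a higher number here means a weaker inhibitor, a lower number a stronger inhibitor), compound 2 gives > 100000 nM, a limit of the assay rather than a number. Compound 1 also gives only a limit, > 100000 nM. The step that the two limits leave unreadable from compound 2 to compound 1 thus cannot be read. Going by the values given here, compound 3 `COc1cc([C@H]2C[C@]2(CO)C(=O)Nc2ccccc2Cl)cc(OC)c1OC` gives 45500 nM in this assay, the only number in the set; the difference between the core of compound 3 and that of compound 2 is not broken down here. Compound 4 `CCOC(=O)[C@]1(C(=O)Nc2ccccc2Cl)C[C@@H]1c1cc(OC)c(OC)c(OC)c1` is unmeasured and differs from compound 3 by ethoxycarbonyl in place of hydroxymethyl on a saturated ring carbon, the same change as from compound 2 to compound 1. Compound 3 sits close to the limit of > 100000 nM in this assay, at which 2 of the 3 values shown sit. Compound 4 is therefore expected near that limit, with the step of a 1.8-fold higher number from compound 3 to compound 4 (0.25 log units; within the scatter) expected small. This expectation rests on compound 3 at 45500 nM and on a step that the two limits leave unreadable from compound 2 to compound 1. Estimate for compound 4: 80000 nM, between 25000 nM and 250000 nM.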

Compound 4, half-maximal inhibitory concentration: > 100000 nM
Compound 4 was reported as a limit; the forecaster's own chance of this, stated with the estimate: 45%; at least 1.2-fold (0.09 log units) between middle value and limit.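

In this assay, ethoxycarbonyl in place of hydroxymethyl on the core of the chlorine-free-of-limit pair gives an at least 2.1-fold higher number from compound 3 to compound 4 (0.34 log units; beyond the scatter), a lower bound on size only, as the upper value is a limit of the assay. The same change on the other core cannot be read, since compound 2 and compound 1 both stand as limits, so the direction holds on one core only and no two step sizes can be compared. The readable range is narrow: the limit of > 100000 nM in this assay, at which 3 of the 4 values shown sit.

On these data alone, how an amine or a carboxylic acid on that saturated ring carbon would read against compound 3 at 45500 nM remains open. Also open, as far as these compounds go, is whether the step persists on a core with a much lower starting number.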